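From a Hydroxypropyl Chain to an Oxolane Carbonyl

The source may report more compounds than this note shows. Statements on the series, on what has been measured and on what is new or still open speak of the compounds shown alone.

Going by the values given here, compound 2 `CC(C)=CC[C@@H](OCC(C)O)C1=CC(=O)c2c(O)ccc(O)c2C1=O` holds the lower of the two numbers measured so far in a functional assay on HeLa cells (Homo sapiens) for cytotoxicity, read by MTT assay (a lower number here means a stronger inhibitor, a higher number a weaker inhibitor), where compound 2 gives 24700 nM. Among the compounds with values here, its only neighbour is compound 1 `CC(=O)OCCO[C@H](CC=C(C)C)C1=CC(=O)c2c(O)ccc(O)c2C1=O`, which in this assay gives 41500 nM. The two are separated by a 1.7-fold lower number from compound 1 to compound 2 (0.23 log units; within the scatter), a gap that the usual scatter of repeated measurements can account for, so the two compounds cannot be ranked against each other.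

Compound 3 `CC(C)=CC[C@@H](OC(=O)C1CCOC1)C1=CC(=O)c2c(O)ccc(O)c2C1=O` has not yet been measured. It differs from compound 2 in one place: (oxolan-3-yl)carbonyl in place of 2-hydroxypropyl on an oxygen on a saturated carbon. Within the data shown here, no measured pair shows this exchange, and the one step in hand, a 1.7-fold lower number from compound 1 to compound 2 (0.23 log units; within the scatter), concerns a different change on the same chain and stayed within the scatter. Both measured compounds sit close together despite their different chain ends, which offers no reason to expect compound 3 to move far.

The step of a 1.2-fold higher number from compound 2 to compound 3 (0.08 log units; within the scatter) is therefore expected to stay within the scatter. Compound 3 is expected to give about 30000 nM in this assay, with a likely range from 10000 nM to 90000 nM.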

Compound 3, half-maximal inhibitory concentration: 73500 nM
Estimate against measurement, compound 3: 2.5-fold (0.39 log units) below; the range from low to high includes it.
By their numbers in this assay, from the lowest: compounds 2, 1 and 3 (each within the scatter of the next, the first and the last beyond it).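

In this assay, going by these compounds alone, the exchange of 2-hydroxypropyl for (oxolan-3-yl)carbonyl on this oxygen gives a 3.0-fold higher number from compound 2 to compound 3 (0.47 log units; beyond the scatter) and is the first step to pass the usual scatter, so the group held on this oxygen can move the number, if only modestly. The same (oxolan-3-yl)carbonyl in place of 2-acetoxyethyl gives a 1.8-fold higher number from compound 1 to compound 3 (0.25 log units; within the scatter) and leaves those two compounds unranked, so the effect of the exchange depends on which group leaves, and compound 3 stands clearly apart only from compound 2. Within the data shown here, nothing measured so far accounts for the step that passes the scatter.

The compounds shown leave open whether the ring or the carbonyl matters more in (oxolan-3-yl)carbonyl, a question that an open-chain butanoyl group on the same oxygen, or an oxolan-3-yl group held there without the carbonyl, could help to settle. On these data alone, it also remains open how far the number would move with a chain ending in an amine or a carboxylic acid at this position.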